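This account rests on a few compounds, and the source may have more. Where it says the series, first, only, none or still open, it means among the compounds named here.

Measured so far:
Compound 1 `O=C(CN(c1nc(Cl)nc2[nH]cnc12)C1CC1)N[C@@H](CO)C(=O)OCc1ccccc1` gives 27.9% in a functional assay on the whole organism (Tail, strain ICR) with Mus musculus as the target, in the tail flick test, with a stated time of 150 min, at a dose of 25 umol/kg by the oral route; a lower number here means a weaker effect, a higher number a stronger effect of the compound at the dose given.
Compound 2 `O=C(CN(c1ncnc2c1ncn2C1CCCCO1)C1CC1)NCC(=O)OCc1ccccc1` gives 7.26% in this assay.
Compound 3 `NCCCC[C@H](NC(=O)CN(c1nc(Cl)nc2[nH]cnc12)C1CC1)C(=O)OCc1ccccc1` gives 9.88% in this assay.

Compound 2 stands at the lowest of the three numbers; compound 3 sits within the scatter of it, while compound 1 lies beyond the scatter above it. The unmeasured compound 4 `O=C(CN(c1ncnc2c1ncn2C1CCCCO1)C1CC1)N[C@@H](CO)C(=O)OCc1ccccc1` carries hydroxymethyl in place of hydrogen on a saturated chain carbon bound to an amide-type nitrogen and a carbonyl carbon. Within the data shown here, no measured step covers exactly this change: the only step at that chain carbon, a number 18 percentage points lower from compound 1 to compound 3 (beyond the scatter), swaps hydroxy for 3-aminopropyl and is modest. Compound 1 and compound 2 differ in two places, so their values give only a loose hint that the hydroxymethyl-bearing compound may read higher. For compound 4 a small upward step a number 8.7 percentage points higher from compound 2 to compound 4 (within the scatter) is expected, near the scatter. Compound 4 is estimated at 16% (range 5% to 32%).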

Compound 4, a percentage reported as activity, at one dose (the size of the read-out at that dose, not a potency): 18.3%
For compound 4 the middle estimate is 2.3 percentage points below the measured one; measured number inside the range.
By their numbers in this assay, from the lowest: compounds 2, 3, 4 and 1 (each within the scatter of the next, the first and the last beyond it).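

At the saturated chain carbon bound to an amide-type nitrogen and a carbonyl carbon, hydroxymethyl in place of hydrogen now has a direct reading in this assay with a number 11 percentage points higher from compound 2 to compound 4 (beyond the scatter) and the step is modest. The earlier step at this carbon compared hydroxymethyl with a longer amine-bearing chain on a different core, whereas this one compares it with plain hydrogen on the core of compound 2. No measurement at hand accounts for this step. On these data alone, whether a methyl group or a carboxylic acid at this carbon would read like hydroxymethyl stays open. Also open, as far as these compounds go, is whether the step from hydrogen to hydroxymethyl holds on the core of compound 1.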